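The source may hold more compounds than are shown below. What is called first, only, known or untested is meant among the compounds shown, and "the series" means these compounds.

This study follows a small family of amides tested in a functional assay on OVCAR-8 cells (Homo sapiens) for antiproliferative activity; a lower number here means a stronger inhibitor, a higher number a weaker inhibitor. Compound 1 `Cn1ncc(Cl)c1-c1cc(C(=O)N[C@@H]2CN[C@H](CCO)C[C@H]2c2ccc(F)c(F)c2)oc1Cl` gives 460 nM. Within the data shown here, compound 2 `Cn1ncc(Cl)c1-c1cc(C(=O)N[C@@H]2CN[C@H](CCN3CCCCC3)C[C@H]2c2ccc(Cl)c(Cl)c2)oc1Cl` gives 1660 nM, the second highest of the three numbers measured so far. Compound 3 `O=C(N[C@@H]1CNCC[C@H]1c1ccc(Cl)cc1)c1ccc(-c2ncnc3c2CCC3O)s1`, built on a different core, gives 24100 nM. Among these three, compound 2 therefore sits between compound 1, whose number is lower, and compound 3, whose number is far higher.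

Compound 4 `Cn1ncc(Cl)c1-c1cc(C(=O)N[C@@H]2CN[C@H](CCN3CCCC3)C[C@H]2c2ccc(Cl)c(Cl)c2)oc1Cl` has not yet been measured in this assay. It differs from compound 2 in one place: pyrrolidin-1-yl in place of piperidin-1-yl on a saturated chain carbon, two bonds along the chain from a saturated ring carbon. The swap changes only the ring at the end of the chain and leaves the rest of the molecule untouched. Among the measured compounds shown here, no pair of measured compounds shows the effect of this particular swap, so nothing measured here speaks to it directly. For a change this small, a step in this assay of no more than the usual scatter is expected, in either direction. Compound 4 is therefore estimated at 1500 nM, with a range from 600 nM to 4000 nM. The expected step of a 1.1-fold lower number from compound 2 to compound 4 (0.04 log units; within the scatter) thus stays within the scatter.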

Compound 4, half-maximal inhibitory concentration: 1840 nM
For compound 4 the middle estimate is 1.2-fold (0.09 log units) below the measured one; low and high end bracket the measured number.
By their numbers in this assay, from the lowest: compound 1; then compounds 2 and 4 (each within the scatter of the next); then compound 3.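

In this assay, putting pyrrolidin-1-yl in place of piperidin-1-yl on a saturated chain carbon, two bonds along the chain from a saturated ring carbon, gives a 1.1-fold higher number from compound 2 to compound 4 (0.04 log units; within the scatter), so this pair cannot be told apart in this assay. This is the only direct reading of this position among the compounds shown: going from a six-membered to a five-membered non-aromatic ring at the end of the chain moves the number by no more than the scatter, on this one shared core. No measurement shown here offers an explanation for this result.

On these data alone, it remains open whether an open-chain amine such as dimethylamino, a morpholin-4-yl ring or a longer chain carrying the same pyrrolidin-1-yl ring would also stay within the scatter. Compound 1, with a hydroxyl group at the end of its chain, differs from compound 2 in more than one place, so the effect of replacing the ring at the chain end with a hydroxyl group cannot be separated from the other changes.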